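Urea series: aryl substituent swap from compound 1

The compounds below may be only part of what the source reports. "The series", "measured", "known", "first", "only" and "open" are said of these compounds alone.

Measured so far:
compound 1 `CCCCc1ccc(NC(=O)N[C@H](C)c2ccccc2)cc1` 32%
compound 2 `CCCCc1ccc(NC(=O)N[C@@H](C)c2ccccc2)cc1` 72%
compound 3 `CC(=O)c1cccc(NC(=O)N[C@H](C)c2ccccc2)c1` 88%

In an ADME assay on the whole organism with Oryza sativa as the target, tested at 1 uM (on this read-out higher numbers stand for a weaker effect at the one concentration tested and lower numbers for a stronger effect), compound 1 stands lowest of the three numbers. Among the measured compounds shown here, the one step measured in one place, a number 40 percentage points higher from compound 1 to compound 2 (beyond the scatter), rests on the fact that compounds 1 and 2 differ only in the configuration as drawn and concerns only the configuration at the saturated chain carbon. Compound 3 carries a different group at a different place and a different configuration, so its number is set beside that of compound 1 without a step between them.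

Compound 4 `C[C@@H](NC(=O)Nc1ccc(F)cc1)c1ccccc1` is to be measured in this assay. It differs from compound 1 in one place: fluoro in place of butyl on an aromatic carbon. For the measured compounds named here, no measured step touches a change on the aromatic carbon of the shared core, so no step size can be carried over; the change is wholly untested and the expectation rests only on where compound 1 stands, at 32%. Compound 4 is therefore estimated at 55%, with a wide range from 25% to 85%, which is expected to mean a number 23 percentage points higher from compound 1 to compound 4 (beyond the scatter).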

Compound 4, a percentage reported as activity, at one concentration (the size of the read-out at that concentration, not a potency): 96%
Compound 4: middle estimate off by 41 percentage points, on the low side; measured number outside the range, above it.
By their numbers in this assay, from the lowest: compound 1; then compound 2; then compounds 3 and 4 (each within the scatter of the next).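

In this assay, the aromatic carbon para to a large group proves sensitive to what it carries: fluoro in place of butyl gives a number 64 percentage points higher from compound 1 to compound 4 (beyond the scatter) and so moves the read-out towards a weaker effect at the one concentration tested. Among the compounds shown here, until now the only measured step concerned the configuration at the saturated chain carbon, so this is the first step showing that the aromatic substituent alone can shift the number by a large amount. Nothing at hand bears on why this swap has such an effect.

Open, as far as these compounds go, is whether a shorter chain such as ethyl, a longer chain such as hexyl, or an amine at this same carbon would keep the number near that of compound 1. Also open, from the compounds shown here alone, is whether fluoro in place of butyl gives a step of similar size in the configuration of compound 2.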